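The source may hold more compounds than are shown below. What is called first, only, known or untested is meant among the compounds shown, and "the series" means these compounds.

Measured compounds:
- Compound 1, `N[C@H](C(=O)Nc1cc2cc[nH]c(=O)c2cc1Cl)C1CCCCC1`: 20 nM
- Compound 2, `CC(C)(C)C[C@H](N)C(=O)Nc1cc2cc[nH]c(=O)c2cc1Cl`: 845 nM
- Compound 3, `N[C@H]1CC[C@@H](C(=O)Nc2cc3cc[nH]c(=O)c3cc2Cl)CC1`: 15 nM

All three share a core and differ only in the group attached to the carbonyl carbon of the amide. In an assay on isolated protein for inhibition of Rho-associated protein kinase 2 (Homo sapiens) (on this read-out lower numbers stand for stronger inhibition and higher numbers for weaker inhibition), compound 3 gives the lowest of the three numbers, although compound 1 sits within the scatter of it; compound 2 is far weaker, as a 56-fold lower number from compound 2 to compound 3 (1.75 log units; beyond the scatter) shows.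

Compound 4, `CC(C)C[C@H](N)C(=O)Nc1cc2cc[nH]c(=O)c2cc1Cl`, is not yet measured. It differs from compound 3 by 1-amino-3-methylbutyl in place of 4-aminocyclohexyl on a carbonyl carbon, a branched open chain in place of the ring.

For the measured compounds named here, two measured steps bear on this. Replacing a ring by a branched chain (a 42-fold higher number from compound 1 to compound 2 (1.63 log units; beyond the scatter)) and the reverse direction (a 56-fold lower number from compound 2 to compound 3 (1.75 log units; beyond the scatter)) were both large. The group entering in compound 4 is close to that of compound 2, so a large rise in this assay is expected, perhaps slightly less than for compound 2.

The estimate for compound 4 is therefore 400 nM, between 100 nM and 1500 nM, corresponding to a 27-fold higher number from compound 3 to compound 4 (1.43 log units; beyond the scatter).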

Compound 4, half-maximal inhibitory concentration: 340 nM
Estimate against measurement, compound 4: 1.2-fold (0.07 log units) above; the range from low to high includes it.
By their numbers in this assay, from the lowest: compounds 3 and 1 (each within the scatter of the next); then compound 4; then compound 2.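

Trimming a single methyl from the end of the open chain already registers, with a 2.5-fold lower number from compound 2 to compound 4 (0.40 log units; beyond the scatter), so this assay responds to a change as small as hydrogen in place of methyl in this group on the carbonyl carbon. That trim recovers only a small part of the gap to the ring compounds, since isobutyl in place of cyclohexyl still gives a 17-fold higher number from compound 1 to compound 4 (1.23 log units; beyond the scatter), and 1-amino-3-methylbutyl in place of 4-aminocyclohexyl gives a 23-fold higher number from compound 3 to compound 4 (1.36 log units; beyond the scatter). Among these four compounds, then, both ring compounds give lower numbers than both open-chain compounds, and the smaller chain of the two gives the lower number.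

No measurement at hand explains these differences. As far as these compounds go, whether a shorter isopropyl chain or a smaller cyclopentyl ring, with the amine kept, would lie closer to the chains or to the cyclohexyl compounds stays open.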